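This account rests on a few compounds, and the source may have more. Where it says the series, first, only, none or still open, it means among the compounds named here.

Working notes on the series. Within the data shown here, in a functional assay for agonist activity at Alpha-1A adrenergic receptor (Homo sapiens) (on this read-out higher numbers stand for an effect only at larger amounts of compound and lower numbers for an effect already at smaller amounts), compound 2 `CSc1ccc(C(F)(F)F)cc1NCC1=NCCN1` gives 10.5 nM, which is the highest of the two numbers measured so far. Among the measured compounds shown here, the only other measured member, compound 1 `CS(=O)(=O)c1ccc(Cl)cc1NCC1=NCCN1`, gives 2.82 nM in this assay, a lower number that lies beyond the scatter; compound 1 is not a single-change neighbour of compound 2, so the two values show only that the combination of groups in compound 1 sits lower than that in compound 2. Compound 3 `CS(=O)(=O)c1ccc(C(F)(F)F)cc1NCC1=NCCN1` is still to be measured in this assay. The change from compound 2 to compound 3 is methylsulfonyl in place of methylsulfanyl on an aromatic carbon. For the measured compounds named here, no step of exactly this kind between measured compounds exists, so the expectation rests on the two values alone. Compound 3 carries the methylsulfonyl group of compound 1 together with the trifluoromethyl group of compound 2, so a move toward the number of compound 1 is expected, of uncertain size. For compound 3 the estimate is 4 nM, between 1.5 nM and 12 nM. The step of a 2.6-fold lower number from compound 2 to compound 3 (0.42 log units; beyond the scatter) is thus expected to be a modest decrease, close to the edge of the scatter.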

Compound 3, half-maximal effective concentration: 1100 nM
Compound 3: the middle estimate sits 280-fold (2.44 log units) below what was measured; the whole stated range lies below it.
By their numbers in this assay, from the lowest: compound 1; then compound 2; then compound 3.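

Working notes, continued. In this assay the aromatic carbon para to the trifluoromethyl group proves highly sensitive to its substituent: methylsulfonyl in place of methylsulfanyl gives a 100-fold higher number from compound 2 to compound 3 (2.02 log units; beyond the scatter) with the trifluoromethyl group unchanged. The methylsulfonyl group does not bring a high number with it in every setting, since trifluoromethyl in place of chloro with methylsulfonyl unchanged gives a 390-fold higher number from compound 1 to compound 3 (2.59 log units; beyond the scatter), so the effect of each of these changes depends on the other group present. Among the three compounds, only the pairing of methylsulfonyl with trifluoromethyl in compound 3 stands far out, and nothing available bears on what lies behind this.

Still open, going by these compounds, is how methylsulfanyl behaves together with chloro, a pairing that would show whether the steps seen here hold as a matching third side of the comparison. Also open, on these data alone, is whether a methoxy group or a nitrile on the same aromatic carbon, or a bromo group in place of trifluoromethyl, would keep the number low or send it up as the methylsulfonyl and trifluoromethyl pairing does.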